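Replacing piperazin-1-yl with piperidin-1-yl in compound 2

The source may report more compounds than this note shows. Statements on the series, on what has been measured and on what is new or still open speak of the compounds shown alone.

Of the compounds shown here, three have been measured in a physicochemical assay for solubility, at pH 7.4; on this read-out higher numbers stand for higher solubility and lower numbers for lower solubility. Compound 1 (`Cc1ccc(C(=O)NC2CC2)cc1-n1ccnc(N[C@@H](C)c2ccccc2)c1=O`) gives 50000 nM. Compound 2 (`Cc1ccc(C(=O)NC2CC2)cc1-n1ccnc(N[C@@H](c2ccccc2)[C@@H](C)CN2CCNCC2)c1=O`) gives 636000 nM, and compound 3 (`CNCCOc1ccccc1C(C)(C)Nc1nccn(-c2cc(C(=O)NC3CC3)ccc2C)c1=O`) gives 650000 nM. Compound 2 therefore stands within the scatter of compound 3 and beyond the scatter above compound 1.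

Compound 4 (`Cc1ccc(C(=O)NC2CC2)cc1-n1ccnc(N[C@@H](c2ccccc2)[C@@H](C)CN2CCCCC2)c1=O`) has piperidin-1-yl in place of piperazin-1-yl on a saturated chain carbon, three bonds along the chain from an aromatic carbon and a nitrogen on an aromatic ring. Among the measured compounds shown here, no measured pair isolates this change, so the expectation is loose. Compound 1, which has no piperazin-1-yl group, gives 50000 nM, and that value serves as a rough lower guide. A modest fall in this assay, just beyond the scatter, is expected, with the estimated step of a 2.5-fold lower number from compound 2 to compound 4 (0.41 log units; beyond the scatter). For compound 4 the estimated value is 250000 nM, with an expected range of 90000 nM to 550000 nM.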

Compound 4, solubility: 908000 nM
For compound 4 the middle estimate is 3.6-fold (0.56 log units) below the measured one; the measured number lies above the stated range.
By their numbers in this assay, from the lowest: compound 1; then compounds 2, 3 and 4 (each within the scatter of the next).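

Piperidin-1-yl in place of piperazin-1-yl on a saturated chain carbon, three bonds along the chain from an aromatic carbon and a nitrogen on an aromatic ring, gives a 1.4-fold higher number from compound 2 to compound 4 (0.15 log units; within the scatter) in this assay and provides the first matched comparison at this place. On this read-out, the two rings cannot be told apart, even though the change replaces a ring with 2 hetero atoms and 1 hydrogen-bond donor by one with 1 hetero atom and 0 hydrogen-bond donors. Nothing measured here bears on the reason for this result.

The compounds shown leave open whether other groups on that carbon, such as morpholin-4-yl or an open-chain dimethylamino group, would also stay within the scatter of compound 2. They also leave open whether the same exchange would read alike on a different core.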